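Ether versus ester at the benzylic oxygen

The source may report more compounds than this note shows. Statements on the series, on what has been measured and on what is new or still open speak of the compounds shown alone.

Measured compounds in a functional assay on HeLa cells (Homo sapiens) for cytotoxicity, read by neutral red uptake, with a stated time of 3 days; a lower number here means a stronger inhibitor, a higher number a weaker inhibitor:
compound 1 `COc1c(F)c(N)c2c(=O)cc(-c3ccc(N)c(F)c3)oc2c1F` gives 34000 nM;
compound 2 `Nc1ccc(-c2cc(=O)c3c(N)c(F)c(C(=O)O)c(F)c3o2)cc1F` gives > 100000 nM, a limit;
compound 3 `CCCCCCCCCC(=O)OCc1c(F)c(N)c2c(=O)cc(-c3ccc(N)c(F)c3)oc2c1F` gives > 100000 nM, a limit.

Compound 3 therefore sits at the limit of > 100000 nM in this assay, at which 2 of the 3 values shown sit, rather than at a number. Compound 4 `CCCOCc1c(F)c(N)c2c(=O)cc(-c3ccc(N)c(F)c3)oc2c1F` carries propyl in place of nonylcarbonyl on an oxygen on a saturated carbon. Going by the values given here, no measured step covers this change; the one measured step, an at least 2.9-fold higher number from compound 1 to compound 2 (0.46 log units; beyond the scatter), concerns a different position and is of modest size. Compound 4 keeps an oxygen on the saturated carbon and is nearer to compound 1 than compound 3 is, so a value at or somewhat above the number for compound 1 is expected, with a fair chance that only a limit is reported. For compound 4 an estimate of 60000 nM (range 20000 nM to 150000 nM) in this assay is made, meaning an expected step of an at least 1.6-fold lower number from compound 3 to compound 4 (0.22 log units; that floor lies within the scatter).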

Compound 4, half-maximal inhibitory concentration: 78000 nM
Compound 4: middle estimate off by 1.3-fold (0.11 log units), on the low side; low and high end bracket the measured number.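

Propyl in place of nonylcarbonyl on the oxygen turns a limit into a measured number in this assay, but the step is only a floor: an at least 1.2-fold lower number from compound 3 to compound 4 (0.10 log units; that floor lies within the scatter). Propoxymethyl in place of carboxy likewise leaves only a floor: an at least 1.2-fold lower number from compound 2 to compound 4 (0.10 log units; that floor lies within the scatter). Propoxymethyl in place of methoxy is the one step with a firm size, a 2.3-fold higher number from compound 1 to compound 4 (0.36 log units; beyond the scatter), so the propyl ether stays weaker than the methoxy.

On these data alone, whether a free hydroxyl or a short acetyl ester on the saturated carbon would give a number remains open, as does the effect of an ether chain longer than propyl.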